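A few compounds are considered here, and "the series" means these few. Any claim that something is new, unique, unknown or untested is made for them only; others in the source may bear on it.

Compound 1, `Clc1ccc(-c2csc(N/N=C/c3cccs3)n2)cc1`: 96%
Compound 2, `COC(=O)c1cc(-c2csc(N/N=C/c3ccc(Cl)cc3Cl)n2)ccc1OCc1ccccc1`: 37.2%

Of the compounds shown here, two have so far been tested in a functional assay, read by spectrophotometry, with a stated time of 15 min, tested at 40 ug/mL; a higher number here means a stronger effect of the compound at the concentration tested, a lower number a weaker effect. Compound 1 gives the highest of the two numbers; the nearest, compound 2, lies lower by a margin beyond the scatter of the assay. Within the data shown here, these two compounds differ from each other in several places at once, so no step in which a single structural change is tied to a single change in inhibition has been measured here.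

Compound 3, `Cc1ccc(-c2csc(N/N=C/c3cccs3)n2)cc1`, has not yet been tested in this assay. Compared with compound 1 it differs in one way: methyl in place of chloro on an aromatic carbon. One group of one heavy atom is replaced by another of one heavy atom, with no ring, no hydrogen-bond donor or acceptor and no charge gained or lost. Among the measured compounds shown here, with no measured step of this kind to lean on, the expectation rests on compound 1 alone. Its inhibition already stands close to the ceiling of the read-out, so there is little room upward; the step of a number 11 percentage points lower from compound 1 to compound 3 (beyond the scatter) is expected to be small and, if anything, downward, possibly within scatter. Compound 3 is therefore estimated to give 85%, in the range 60% to 98%.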

Compound 3, a percentage reported as inhibition, at one concentration (the size of the read-out at that concentration, not a potency): 97%
Compound 3: middle estimate off by 12 percentage points, on the low side; the measured number falls inside the stated range.
By their numbers in this assay, from the lowest: compound 2; then compounds 1 and 3 (each within the scatter of the next).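

In this assay, putting methyl in place of chloro on an aromatic carbon, para to a large group, gives a number 1 percentage points higher from compound 1 to compound 3 (within the scatter) and so leaves the two compounds indistinguishable. This is the first step shown in which only one place changes, and it indicates that chloro at this position is not required for strong inhibition at the concentration tested, since methyl serves equally well in this read-out. No measured property of either group is available to explain the result.

Compound 1 at 96% and compound 3 at 97% both lie close to the top of the percentage scale, so a single concentration leaves open whether a real difference in potency is hidden there, a question that only tests at lower concentrations could settle. On these data alone, it also remains open how far this tolerance extends on the same carbon, for instance to an amine, a carboxylic acid or a longer chain such as butyl, each of which is a much larger or a different kind of change than one single-atom group for another.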